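Replacing Methyl on the Ring Amine Nitrogen

The compounds below may be only part of what the source reports. "The series", "measured", "known", "first", "only" and "open" are said of these compounds alone.

In an ADME assay on L02 cells (Homo sapiens) for cytotoxicity, read by MTT assay, with a stated time of 72 h (a higher number here means a weaker inhibitor, a lower number a stronger inhibitor), compound 1 (`COc1cc(/C=C2\CN(C)C/C(=C\c3cc(OC)c(OC)c(OC)c3)C2=O)cc(OC)c1OC`) gives 26400 nM. Compound 2 (`CCCN1C/C(=C\c2ccc(OC)c(OC)c2)C(=O)/C(=C/c2ccc(OC)c(OC)c2)C1`) gives 21000 nM, and the two values lie within the usual scatter of each other. Compound 3 (`COc1cc(/C=C2\CN(C(=O)CCC(=O)O)C/C(=C\c3cc(OC)c(OC)c(OC)c3)C2=O)cc(OC)c1OC`) departs from compound 1 by (2-carboxyethyl)carbonyl in place of methyl on an amine nitrogen in a ring, with (2-carboxyethyl)carbonyl in place of methyl on an amine nitrogen in a ring. For the measured compounds named here, no measured pair shows this change alone, so the expectation has little to rest on. The expected step, a 1.3-fold lower number from compound 1 to compound 3 (0.12 log units; within the scatter), is none beyond the scatter. Compound 3 is estimated at 20000 nM, with an expected range of 6000 nM to 60000 nM.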

Compound 3, half-maximal inhibitory concentration: > 60000 nM
Compound 3 gave a limit, no number; the forecaster's own chance of this, stated with the estimate: 10%; middle value at least 3.0-fold (0.47 log units) from the limit.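

Placing (2-carboxyethyl)carbonyl in place of methyl on this amine nitrogen in a ring gives an at least 2.2-fold higher number from compound 1 to compound 3 (0.35 log units; beyond the scatter), the first change at this position that can be read alone. In this assay compound 3 gives > 60000 nM, which is a limit and not a number. The full size of the step therefore stays unknown because the reading ends at a limit: the limit of > 60000 nM in this assay, at which 1 of the 3 values shown sits.

The compounds shown leave open whether the carbonyl on the nitrogen or the carboxylic acid at the chain end carries this step. They also leave open how an ester in place of that acid, or a chain ending in an amine, would read in this assay.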